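Cytotoxicity of the series: the step to compound 4

The source may hold more compounds than are shown below. What is called first, only, known or untested is meant among the compounds shown, and "the series" means these compounds.

The series keeps one core and varies the group on an aromatic nitrogen of the five-membered ring. Compound 1 `COc1ccc(-n2c(=O)n(Cc3cc4cc(Cl)ccc4n3CCCC#N)c3cnccc32)cc1OC` carries 3,4-dimethoxyphenyl there; in an ADME assay on HeLa cells (Homo sapiens) for cytotoxicity, read by ATP content, with a stated time of 3 days (a higher number here means that more compound is tolerated, a lower number that less compound is tolerated), compound 1 gives > 50000 nM, which is a limit of the assay and not a number. Compound 2 `N#CCCCn1c(Cn2c(=O)n(-c3ccncc3F)c3ccncc32)cc2cc(Cl)ccc21` carries 3-fluoropyridin-4-yl, and in this assay compound 2 gives > 50000 nM, again a limit. Compound 3 `N#CCCCn1c(Cn2c(=O)n(-c3ncccn3)c3ccncc32)cc2cc(Cl)ccc21` carries pyrimidin-2-yl, and in this assay compound 3 gives > 50000 nM, also a limit. Compound 3 thus stands with the other two at the limit of > 50000 nM in this assay, at which 3 of the 3 values shown sit. The steps a step that the two limits leave unreadable from compound 1 to compound 2, a step that the two limits leave unreadable from compound 1 to compound 3 and a step that the two limits leave unreadable from compound 2 to compound 3 cannot be sized.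

Compound 4 `COc1ccc(-n2c(=O)n(Cc3cc4cc(Cl)ccc4n3CCCC#N)c3cnccc32)c(C)c1` differs from compound 3 by 4-methoxy-2-methylphenyl in place of pyrimidin-2-yl on an aromatic nitrogen. Within the data shown here, no measured step bears directly on this exchange, and the three measured steps give no size to lean on. The step of a number no higher from compound 3 to compound 4 (the limit leaves the size open) is expected to be none beyond the scatter because every value shown sits at the limit of > 50000 nM in this assay, at which 3 of the 3 values shown sit. Compound 4 is expected to give 50000 nM in this assay, between 30000 nM and 100000 nM.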

Compound 4, half-maximal cytotoxic concentration: > 50000 nM
Compound 4: a limit, no number (the forecaster's own chance of this, stated with the estimate: 85%); the middle value lies on the limit itself.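

In this assay compound 4 gives > 50000 nM, a limit and not a number. No step from compound 4 to compound 1, compound 2 or compound 3 can be read: the limit of > 50000 nM in this assay, at which 4 of the 4 values shown sit.

The compounds shown leave open whether the group on the aromatic nitrogen has any effect in this assay, as none of them gives a number.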